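Adding a second methoxy to compound 1

The source may hold more compounds than are shown below. What is called first, only, known or untested is meant among the compounds shown, and "the series" means these compounds.

Going by the values given here, compound 1 `COc1ccc2[nH]cc(/C=C(\C#N)C(=O)c3c[nH]c4ccccc34)c2c1` is the only compound with a number in a functional assay on MIA PaCa-2 cells (Homo sapiens) for cytotoxicity, read by WST assay, with a stated time of 24 h; a higher number here means a weaker inhibitor, a lower number a stronger inhibitor: compound 1 gives 21200 nM. Compound 2 `COc1ccc2c(/C=C(\C#N)C(=O)c3c[nH]c4cc(OC)ccc34)c[nH]c2c1` reads > 50000 nM, which is a limit of the assay. Compound 3 `N#C/C(=C\c1c[nH]c2ccc(Br)cc12)C(=O)c1c[nH]c2ccc(Br)cc12` reads > 50000 nM, also a limit. Compound 4 `COc1ccc2[nH]cc(/C=C(\C#N)C(=O)c3c[nH]c4ccc(OC)cc34)c2c1` has methoxy in place of hydrogen on an aromatic carbon of compound 1: methoxy in place of hydrogen on an aromatic carbon. Among the compounds with values here, no measured pair isolates this change. A modest weakening in this assay is expected, resting on compound 2 at > 50000 nM, a limit, which also carries two methoxy groups. The estimated step is a 1.7-fold higher number from compound 1 to compound 4 (0.22 log units; within the scatter). Compound 4 is estimated at 35000 nM, with an expected range of 12000 nM to 50000 nM.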

Compound 4, half-maximal inhibitory concentration: 28500 nM
Compound 4: the middle estimate sits 1.2-fold (0.09 log units) above what was measured, within the range that was stated.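

On this aromatic carbon, meta to a fused ring and para to a fused ring, methoxy in place of hydrogen gives a 1.3-fold higher number from compound 1 to compound 4 (0.13 log units; within the scatter) in this assay. Going by these compounds alone, this is the first readable step, and it shows that this change at this position cannot be told from repeat scatter. Little room remains for reading weaker compounds in this assay: the limit of > 50000 nM in this assay, at which 2 of the 4 values shown sit.

As far as these compounds go, whether this position accepts other groups stays open, for instance an amine, a carboxylic acid or a longer chain such as butoxy. How much of the number depends on the methoxy of compound 1 is also unresolved.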